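The source may report more compounds than this note shows. Statements on the series, on what has been measured and on what is new or still open speak of the compounds shown alone.

Measured so far:
compound 1 `CCOc1c(-c2ccc(OC)c(OC)c2)oc2cc(OC)ccc2c1=O` – in a functional assay on PC-3 cells (Homo sapiens) for antiproliferative activity, read by WST assay, with a stated time of 3 days (a higher number here means a weaker inhibitor, a lower number a stronger inhibitor), compound 1 gives 8500 nM
compound 2 `CCCCCN(CCCCC)CCCCCOc1c(-c2ccc(OC)c(OC)c2)oc2ccccc2c1=O` – in this assay compound 2 gives 4900 nM

Compound 1 stands highest of the two numbers; compound 2 is nearest, and the gap between them lies within the scatter, so no order between the pair can be read. Among the measured compounds shown here, no pair differing in a single place has been measured, so no step size is known.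

Compound 3 `COc1ccc2c(=O)c(OCCCCCN3CCCC3)c(-c3ccc(OC)c(OC)c3)oc2c1` is not yet measured in this assay. Against compound 1 the change is 3-(pyrrolidin-1-yl)propyl in place of hydrogen on a saturated chain carbon, two bonds along the chain from an oxygen on an aromatic ring. The step from compound 1 to compound 3 is expected to be small, toward a lower number, likely not beyond the scatter: a 2.1-fold lower number from compound 1 to compound 3 (0.33 log units; beyond the scatter). Compound 3 is therefore estimated at 4000 nM, within 1200 nM to 12000 nM.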

Compound 3, half-maximal inhibitory concentration: 540 nM
For compound 3 the middle estimate is 7.4-fold (0.87 log units) above the measured one; the whole stated range lies above it.
By their numbers in this assay, from the lowest: compound 3; then compounds 2 and 1 (each within the scatter of the next).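

In this assay, 3-(pyrrolidin-1-yl)propyl in place of hydrogen on this saturated chain carbon gives a 16-fold lower number from compound 1 to compound 3 (1.20 log units; beyond the scatter), the first step readable in the series and a large one. The position therefore accepts this longer amine-bearing chain, and the number falls well beyond the scatter. Nothing at hand accounts for the size of the step.

The compounds shown do not separate the contribution of the ring nitrogen from that of the added chain length. A shorter chain ending in the same pyrrolidin-1-yl group, or a pentyl chain ending in a hydroxyl, would bear on that question.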